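The source may hold more compounds than are shown below. What is called first, only, known or untested is meant among the compounds shown, and "the series" means these compounds.

Measured compounds:
compound 1, `COC(C)(C)CCCC(C)C/C=C/C(C)=C/C(=O)OC(C)(C)C`: 6.36
compound 2, `C=C(C)CCCC(C)C/C=C/C(C)=C/C(=O)OC(C)C`: 6.6
compound 3, `CCSC(=O)/C=C(C)/C=C/CC(C)CCCC(C)C`: 7.98

In a physicochemical assay for lipophilicity (a lower number here means a more polar compound, a higher number a more lipophilic compound), compound 1 holds the lowest of the three numbers. Its nearest neighbour is compound 2, whose value lies within the scatter of the number for compound 1, so no order can be read between those two. Compound 3 stands furthest away, beyond the scatter, with the highest value of the three.

The step from compound 1 leads to compound 4, `COC(C)(C)CCCC(C)C/C=C/C(C)=C/C(=O)SC(C)C`, which has not yet been measured in this assay. The change is: isopropylsulfanyl in place of tert-butoxy on a carbonyl carbon. For the measured compounds named here, no measured pair shows this same change on its own, so its size cannot be read directly from the data. Going by the values given here, compound 3, the one compound carrying a sulfur in the corresponding position, gives the highest number of the three, and a rise in this assay is expected for compound 4 because compound 3 gives 7.98. The expected step of a number 0.64 log units higher from compound 1 to compound 4 (beyond the scatter) is an estimate, beyond the scatter and upward. Compound 4 is expected to give 7, within a range from 6.5 to 7.6.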

Compound 4, partition coefficient: 7.19
Estimate against measurement, compound 4: 0.19 log units below; measured number inside the range.
By their numbers in this assay, from the lowest: compounds 1 and 2 (each within the scatter of the next); then compound 4; then compound 3.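

For the compounds shown here, replacing tert-butoxy with isopropylsulfanyl on a carbonyl carbon gives, in this assay, a number 0.83 log units higher from compound 1 to compound 4 (beyond the scatter) as the first step here that follows a change in one place only. It shows that this position can move the number beyond the scatter, even though the entering group has fewer heavy atoms than the one it replaces and the same count of hydrogen-bond acceptors. Nothing on hand accounts for the size of this step.

The compounds shown do not separate the exchange of oxygen for sulfur from the exchange of tert-butyl for isopropyl, since none carries tert-butylsulfanyl on this carbonyl carbon of the core of compound 1. They also leave open what an amine-derived amide or a carboxylic acid would give at the same place.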